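Trifluoromethyl for Hydroxymethyl: Cytotoxicity Outlook

This account rests on a few compounds, and the source may have more. Where it says the series, first, only, none or still open, it means among the compounds named here.

Among the compounds with values here, compound 2 `O=[N+]([O-])c1c(CS(=O)(=O)c2ccccc2)nc2c(-c3cccc(CO)c3)cc(Cl)cn12` is one of two compounds measured in an ADME assay on HepG2 cells (Homo sapiens) for cytotoxicity, read by MTT assay, with a stated time of 72 h; on this read-out higher numbers stand for lower toxicity in this test and lower numbers for higher toxicity in this test. For compound 2 the value is a limit of the assay, > 25000 nM. Compound 1 `O=[N+]([O-])c1c(CS(=O)(=O)c2ccccc2)nc2c(-c3ccc(Cl)cc3)cc(Cl)cn12` also sits at a limit; in this assay compound 1 gives > 3900 nM. Within the data shown here, the only measured step, a step that the two limits leave unreadable from compound 1 to compound 2, rests on the limit of > 25000 nM in this assay, at which 1 of the 2 values shown sits, and the limit of > 3900 nM in this assay, at which 1 of the 2 values shown sits, and has no readable size. Compound 3 `O=[N+]([O-])c1c(CS(=O)(=O)c2ccccc2)nc2c(-c3cccc(C(F)(F)F)c3)cc(Cl)cn12` differs from compound 2 by trifluoromethyl in place of hydroxymethyl on an aromatic carbon. Among the measured compounds shown here, no measured step bears on this change, so no direction can be drawn beyond the scatter. Compound 3 is expected to give 25000 nM, within 8000 nM to 60000 nM, a step of a number no higher from compound 2 to compound 3 (the limit leaves the size open) that is expected to stay within the scatter.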

Compound 3, half-maximal cytotoxic concentration: > 12500 nM
Compound 3 ended at the assay's limit; the forecaster's own chance of this, stated with the estimate: 60%; the middle value does not contradict the limit.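

Within the data shown here, compound 1, compound 2 and compound 3 all stand at limits in this assay, so no step among them can be read. The compounds shown leave open whether 4-chlorophenyl, 3-(hydroxymethyl)phenyl and 3-(trifluoromethyl)phenyl differ at all in this assay.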